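The source may report more compounds than this note shows. Statements on the series, on what has been measured and on what is new or still open speak of the compounds shown alone.

Compound 1 `Cn1cccc1C(=O)/C=C/c1ccc2c(c1)B(O)OC2` carries a 1-methyl-1H-pyrrol-2-yl group on the carbonyl carbon of the shared core. In a functional assay on SK-OV-3 cells (Homo sapiens) for cytotoxicity, read by MTT assay, with a stated time of 48 h (a lower number here means a stronger inhibitor, a higher number a weaker inhibitor), compound 1 gives 93600 nM, the highest of the three numbers measured here. Its two companions place a six-membered carbon ring on that carbonyl carbon instead: compound 2 `CCc1ccc(C(=O)/C=C/c2ccc3c(c2)B(O)OC3)cc1` gives 4400 nM in this assay, and compound 3 `O=C(/C=C/c1ccc2c(c1)B(O)OC2)c1ccc(OCc2ccccc2)cc1` gives 6000 nM. Within the data shown here, the one step measured between them, a 1.4-fold higher number from compound 2 to compound 3 (0.13 log units; within the scatter), shows that the swap of a group on the aromatic carbon of that ring leaves the number essentially unchanged, while both compounds sit far below compound 1.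

Compound 4 `O=C(/C=C/c1ccc2c(c1)B(O)OC2)c1cccc(F)c1` has not yet been measured. It differs from compound 1 by 3-fluorophenyl in place of 1-methyl-1H-pyrrol-2-yl on a carbonyl carbon. Among the measured compounds shown here, no measured step covers exactly this exchange, but compounds 2 and 3 both show what an aromatic carbon ring on the carbonyl carbon does against the pyrrole of compound 1, and the substituent on that ring mattered little in the step from compound 2 to compound 3. Compound 4 is therefore expected to fall near compounds 2 and 3, with an expected step of a 14-fold lower number from compound 1 to compound 4 (1.16 log units; beyond the scatter). The estimate for compound 4 is 6500 nM, with a range from 2500 nM to 20000 nM.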

Compound 4, half-maximal inhibitory concentration: 4800 nM
For compound 4 the middle estimate is 1.4-fold (0.13 log units) above the measured one; the measured number falls inside the stated range.
By their numbers in this assay, from the lowest: compounds 2, 4 and 3 (each within the scatter of the next); then compound 1.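

In this assay, among these compounds, replacing 1-methyl-1H-pyrrol-2-yl with 3-fluorophenyl on the carbonyl carbon gives a 20-fold lower number from compound 1 to compound 4 (1.29 log units; beyond the scatter) and is the one step here that reads this kind of exchange directly, showing that the position responds strongly to the group it carries. Compound 4 also extends the picture from compounds 2 and 3 to a third six-membered aromatic ring of carbon only, this one bearing fluorine, and compounds 2, 3 and 4 all lie within the scatter of one another, so among these three the substituent on the ring makes no readable difference. Nothing measured here accounts for the size of the step.

The exchange swaps the ring size and removes both the ring nitrogen and its methyl in a single move, so the compounds shown cannot say which of these changes carries the step. Also open, on these data alone, is whether a plain phenyl, a pyridin-3-yl ring, or a phenyl bearing a dimethylamino group or a carboxylic acid would stay with compounds 2, 3 and 4 or move toward compound 1.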